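This account rests on a few compounds, and the source may have more. Where it says the series, first, only, none or still open, it means among the compounds named here.

Of the compounds shown here, three sharing one core have been measured so far in a functional assay on MCF7 cells (Homo sapiens) for inhibition, read by MTT assay, with a stated time of 48 h (a higher number here means a weaker inhibitor, a lower number a stronger inhibitor), and two of them sit together. Compound 1 `Oc1cccc(C(c2c[nH]c3ccc(Br)cc23)c2c[nH]c3ccc(Br)cc23)c1` gives 2800 nM and compound 3 `Brc1ccc2[nH]cc(C(c3c[nH]c4ccc(Br)cc34)C3CCCCC3)c2c1` gives 4100 nM in this pair, with a 1.5-fold higher number from compound 1 to compound 3 (0.17 log units; within the scatter) as the step that joins them. Compound 2 `COc1cccc(C(c2c[nH]c3ccc(Br)cc23)c2c[nH]c3ccc(Br)cc23)c1OC` lies far off at 89000 nM and the return to cyclohexyl is a 22-fold lower number from compound 2 to compound 3 (1.34 log units; beyond the scatter) for that pair.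

Compound 4 `Clc1ccc(C(c2c[nH]c3ccc(Br)cc23)c2c[nH]c3ccc(Br)cc23)cc1` is still unmeasured. It swaps the cyclohexyl of compound 3 for 4-chlorophenyl on a saturated chain carbon bound to two aromatic carbons, a change counted as 4-chlorophenyl in place of cyclohexyl on a saturated chain carbon bound to two aromatic carbons here.

Compound 1 shows that an aromatic ring can take the place of cyclohexyl with no step beyond the scatter. Compound 2 shows that ring substituents can still matter, with a 32-fold higher number from compound 1 to compound 2 (1.50 log units; beyond the scatter) as a large warning. The expected change is therefore a 1.2-fold higher number from compound 3 to compound 4 (0.09 log units; within the scatter) in this assay and this estimate means no step beyond the scatter, with more room towards higher numbers.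

The estimate for compound 4 is 5000 nM within an expected range of 1500 nM to 25000 nM for this measurement.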

Compound 4, half-maximal inhibitory concentration: 3500 nM
For compound 4 the middle estimate is 1.4-fold (0.15 log units) above the measured one; the range from low to high includes it.
By their numbers in this assay, from the lowest: compounds 1, 4 and 3 (each within the scatter of the next); then compound 2.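

In this assay, 4-chlorophenyl on a saturated chain carbon bound to two aromatic carbons reads the same as cyclohexyl within the scatter (a 1.2-fold lower number from compound 3 to compound 4 (0.07 log units; within the scatter)) and the same as 3-hydroxyphenyl (a 1.3-fold higher number from compound 1 to compound 4 (0.10 log units; within the scatter)). A second substituted aromatic ring therefore joins the close group, and this one carries chlorine, so compound 2 now stands alone among these compounds (a 25-fold lower number from compound 2 to compound 4 (1.41 log units; beyond the scatter)). Nothing measured here explains these values.

The compounds shown leave open whether a ring with a single methoxy group would stay with the close group or fall away with compound 2. They also leave open how a carboxylic acid or an amine on the ring, or a longer alkyl chain in its place, would read in this assay.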